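Pyrrole to Triazole on the Salicylate Core

The compounds below may be only part of what the source reports. "The series", "measured", "known", "first", "only" and "open" are said of these compounds alone.

compound 1, `O=C(O)c1cc(-n2cccc2)ccc1O`, 50 mg/kg
compound 2, `O=C(O)c1cc(-c2ccncn2)ccc1O`, > 200 mg/kg (a limit)
compound 3, `CCCCOC(=O)Oc1ccc(-n2cccc2)cc1C(=O)O`, 52 mg/kg

In a functional assay on the whole organism for inhibition, with Rattus norvegicus as the target, read by paw edema (a higher number here means that more compound is needed for the effect, a lower number that less compound is needed), compound 1 gives 50 mg/kg, the lowest of the two numbers shown. Its nearest neighbour is compound 3, with a 1.0-fold higher number from compound 1 to compound 3 (0.02 log units; within the scatter), a difference that lies within the scatter. Compound 2 reaches only a limit in this assay, > 200 mg/kg.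

Compound 4 `O=C(O)c1cc(-n2cncn2)ccc1O` has not yet been measured. It differs from compound 1 as follows: 1H-1,2,4-triazol-1-yl in place of 1H-pyrrol-1-yl on an aromatic carbon. Among the measured compounds shown here, the only measured step, a 1.0-fold higher number from compound 1 to compound 3 (0.02 log units; within the scatter), alters the substituent on the oxygen and leaves the aromatic ring untouched, so it does not bear on this change. For the measured compounds named here, the sole comparison for a change of the aromatic ring is compound 2, and that compound sits at the limit (the limit of > 200 mg/kg in this assay, at which 1 of the 3 values shown sits). With no numbered step to lean on, the expectation for compound 4 is a higher number than for compound 1, roughly a 2.6-fold higher number from compound 1 to compound 4 (0.41 log units; beyond the scatter), with a real chance that only a limit is reported. Compound 4 is therefore estimated at 130 mg/kg, within a range from 50 mg/kg to 300 mg/kg.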

Compound 4, dose for half-maximal effect: 200 mg/kg
Compound 4: middle estimate off by 1.5-fold (0.19 log units), on the low side; measured number inside the range.
By their numbers in this assay, from the lowest: compounds 1 and 3 (each within the scatter of the next); then compound 4.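

In this assay, the ring carried on the aromatic carbon meta to a carboxy group and para to a hydroxy group matters, with a 4.0-fold higher number from compound 1 to compound 4 (0.60 log units; beyond the scatter) when 1H-1,2,4-triazol-1-yl replaces 1H-pyrrol-1-yl. Both groups are five-membered aromatic rings with the same count of heavy atoms, so this step comes with a change in ring atoms, from one hetero atom to three, and not with a change in ring size. Among the compounds shown here, compound 2 gives only a limit, so this is the first ring change at this position whose size can be read: the limit of > 200 mg/kg in this assay, at which 1 of the 4 values shown sits.

A 1H-imidazol-1-yl or 1H-pyrazol-1-yl group at this place would show whether the step follows the number of ring nitrogens or their arrangement. Also open, on these data alone, is whether butoxycarbonyl on the hydroxy oxygen of compound 4 would leave the number as unchanged as in the earlier pair, which shows a 1.0-fold higher number from compound 1 to compound 3 (0.02 log units; within the scatter) in the same assay.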